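Series notes: isobutyl to sec-butyl on the ring amide nitrogen

The source may hold more compounds than are shown below. What is called first, only, known or untested is meant among the compounds shown, and "the series" means these compounds.

Measured so far:
- compound 1, `CC1=C(O)[C@@H](C/C(C)=C\CC[C@H](C)/C=C/C=C(\C)CCCc2ccoc2)OC1=O`
- compound 2, `CC1=C(O)[C@H](C/C(C)=C\CC[C@H](C)/C=C/C=C(\C)CCCC2=CCN(CCC(C)C)C2=O)OC1=O`
- compound 3, `CC1=C(O)[C@@H](C/C(C)=C\CC[C@H](C)/C=C/C=C(\C)CCCC2=CCN(CCC(C)C)C2=O)OC1=O`

In a functional assay on SK-OV-3 cells (Homo sapiens) for cytotoxicity (a lower number here means that less compound is needed, a higher number that more compound is needed for the effect), compound 1 gives 9.6 ug/mL, compound 2 gives 5.3 ug/mL and compound 3 gives 4 ug/mL. Compound 2 sits second highest of the three; its gaps to compound 3 and to compound 1 are both within the scatter, so no order among them is claimed. The two measured steps are of another kind: a 2.4-fold lower number from compound 1 to compound 3 (0.38 log units; beyond the scatter), and a 1.3-fold lower number from compound 2 to compound 3 (0.12 log units; within the scatter), the latter small because of the fact that compounds 2 and 3 differ only in the configuration as drawn. Compound 4, `CCC(C)CN1CC=C(CCC/C(C)=C/C=C/[C@@H](C)CC/C=C(/C)C[C@@H]2OC(=O)C(C)=C2O)C1=O`, differs from compound 2 by sec-butyl in place of isobutyl on a saturated chain carbon bound to an amide-type nitrogen in a ring. Neither measured step touches this chain. For compound 4 no step beyond the scatter is expected in either direction, no change at the digits printed from compound 2 to compound 4 (within the scatter). Compound 4 is therefore estimated at 5.3 ug/mL, within 2.6 ug/mL to 10.6 ug/mL.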

Compound 4, concentration for half-maximal effect: 6.9 ug/mL
The estimate for compound 4 lay 1.3-fold (0.11 log units) below the measured number; the measured number falls inside the stated range.
By their numbers in this assay, from the lowest: compounds 3, 2, 4 and 1 (each within the scatter of the next, the first and the last beyond it).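

Sec-butyl in place of isobutyl on a saturated chain carbon bound to an amide-type nitrogen in a ring gives a 1.3-fold higher number from compound 2 to compound 4 (0.11 log units; within the scatter) in this assay. Among these compounds, this is the only reading so far at this position, and it shows that these two butyl groups cannot be told apart in this assay's numbers. Nothing at hand bears on this step.

Going by these compounds, whether a longer chain such as n-octyl, a benzyl group or an amine at this position would give a step beyond the scatter remains open. The same holds for a carboxylic acid there.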